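Swapping Nitro for Trifluoromethyl: Cytotoxicity Outlook

The compounds below may be only part of what the source reports. "The series", "measured", "known", "first", "only" and "open" are said of these compounds alone.

Compound 3 `O=[N+]([O-])c1cc(-c2nnc(SCc3ccc(Cl)c(Cl)c3)n2Cc2ccccc2)cc([N+](=O)[O-])c1` is one of three close relatives tested in an ADME assay on HepG2 cells (Homo sapiens) for cytotoxicity, with a stated time of 48 h; a higher number here means a weaker inhibitor, a lower number a stronger inhibitor. In this assay compound 3 gives > 30000 nM, which is a limit of the assay rather than a number. Compound 1 `O=[N+]([O-])c1cc(-c2nnc(SCc3ccc(Br)cc3)n2Cc2ccccc2)cc([N+](=O)[O-])c1` likewise gives > 30000 nM in this assay, again a limit. Compound 2 `O=[N+]([O-])c1cc(-c2nnc(SCc3ccc(Cl)cc3)n2Cc2ccccc2)cc([N+](=O)[O-])c1` gives > 30000 nM in this assay, also a limit. Because all three sit at the limit of > 30000 nM in this assay, at which 3 of the 3 values shown sit, the steps between them cannot be sized: a step that the two limits leave unreadable from compound 1 to compound 2, a step that the two limits leave unreadable from compound 1 to compound 3 and a step that the two limits leave unreadable from compound 2 to compound 3 all stay unreadable. Compound 4 `O=[N+]([O-])c1cc(-c2nnc(SCc3ccc(Cl)c(Cl)c3)n2Cc2ccccc2)cc(C(F)(F)F)c1` is the next relative and has not yet been measured. It differs from compound 3 in one place: trifluoromethyl in place of nitro on an aromatic carbon. Among the measured compounds shown here, none of the measured steps touches the six-membered aromatic ring of carbon only that carries the nitro group, so they offer no guide to the direction of this change; they show only that every compound so far has stayed at the limit. The step from compound 3 to compound 4 is therefore expected to be small, an at least 1.2-fold lower number from compound 3 to compound 4 (0.07 log units; that floor lies within the scatter). Compound 4 is expected to give about 25000 nM in this assay, within a range from 8000 nM to 80000 nM, with a fair chance that only a limit is reported again.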

Compound 4, half-maximal inhibitory concentration: > 30000 nM
Compound 4 gave a limit, no number; the forecaster's own chance of this, stated with the estimate: 65%; at least 1.2-fold (0.07 log units) between middle value and limit.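

No step can be read from compound 3 to compound 4, because each gives a limit of the assay rather than a number: the limit of > 30000 nM in this assay, at which 4 of the 4 values shown sit.

The compounds shown leave open whether trifluoromethyl in place of nitro shifts the read-out at all, and how far any of the four lies past that limit.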